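Stereochemical variants of a peroxide-tetrahydrofuran acid series

This account rests on a few compounds, and the source may have more. Where it says the series, first, only, none or still open, it means among the compounds named here.

Measured in a functional assay on DU-145 cells (Homo sapiens) for cytotoxicity; a lower number here means a stronger inhibitor, a higher number a weaker inhibitor:
- compound 1 `C=CCC/C=C\C=C/CCCCCCCC[C@H]1CC[C@H]([C@@H]2CC[C@@H](CC(=O)O)OO2)O1` gives 0.1 ug/mL
- compound 2 `C=CCCC/C=C/C=C\CCCCCCCC[C@@H]1CC[C@@H]([C@@H]2CC[C@@H](CC(=O)O)OO2)O1` gives 0.1 ug/mL
- compound 3 `C=CCC/C=C\C=C/CCCCCCCC[C@H]1CC[C@@H]([C@@H]2CC[C@@H](CC(=O)O)OO2)O1` gives 0.1 ug/mL
- compound 4 `C=CCCC/C=C/C=C\CCCCCCCC[C@H]1CC[C@H]([C@@H]2CC[C@@H](CC(=O)O)OO2)O1` is not yet measured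

Compound 2 stands level with compounds 1 and 3 in this assay; all three sit at the same digits, within the scatter of one another, so no order among them can be read.

For the measured compounds named here, the only measured step that bears on the present question is the configurational one: no change at the digits printed from compound 1 to compound 3 (within the scatter), a result that rests on (the fact that compounds 1 and 3 differ only in the configuration as drawn), since those two compounds share every atom and bond and differ only in the drawing of one stereocentre. The change from compound 2 to compound 4 is of the same kind: the two compounds have the same atoms and bonds and differ only in configuration as drawn: 2 of 6 stereo elements differ; a stereocentre at a saturated ring carbon is drawn R in compound 2 and S in compound 4; a stereocentre at a saturated ring carbon is drawn S in compound 2 and R in compound 4. One inverted saturated ring carbon left the read-out untouched; there is no measured case of two, but nothing in the series suggests that a second inversion should behave otherwise.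

Compound 4 is therefore expected to stay within the scatter, that is no change at the digits printed from compound 2 to compound 4 (within the scatter), and its estimated value is 0.1 ug/mL, with a range from 0.05 ug/mL to 0.25 ug/mL.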

Compound 4, half-maximal inhibitory concentration: 0.1 ug/mL
The estimate for compound 4 equals the measured number at the digits printed, within the range that was stated.
By their numbers in this assay, from the lowest: compounds 1, 2, 3 and 4 (each within the scatter of the next).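

In this assay, for the compounds shown here, the first case of two saturated ring carbons changing their drawn configuration together gives no change at the digits printed from compound 2 to compound 4 (within the scatter), whereas the earlier compounds covered only a single such change. A chain difference can now also be read, as a group of 7 heavy atoms (7 carbon; no ring) in place of a group of 6 heavy atoms (6 carbon; no ring), on a double-bonded chain carbon bound to a double-bonded chain carbon, gives no change at the digits printed from compound 1 to compound 4 (within the scatter). The configurational reading is a clean one, with no change of atoms or bonds mixed in: the fact that compounds 2 and 4 differ only in the configuration as drawn

All four compounds keep the carboxylic acid and the shared core, so these results do not say how a methyl ester or an amide would read. Going by these compounds, a fully saturated chain or a much shorter chain also remains open.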